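Replacing ethoxycarbonyl with hydroxymethyl in compound 3

The compounds below may be only part of what the source reports. "The series", "measured", "known", "first", "only" and "open" are said of these compounds alone.

In a functional assay on A549 cells (Homo sapiens) for cytotoxicity, read by MTT assay, with a stated time of 48 h (a lower number here means a stronger inhibitor, a higher number a weaker inhibitor), compound 1 `CCOC(=O)C1(C(=O)Nc2ccccc2)CC1c1cc(OC)c(OC)c(OC)c1` gives 31500 nM; 48600 nM (2 entries). Compound 2 `CCOC(=O)[C@]1(C(=O)Nc2ccccc2)C[C@H]1c1cc(OC)c(OC)c(OC)c1` gives 37300 nM, and compound 3 `CCOC(=O)[C@]1(C(=O)Nc2ccccc2)C[C@@H]1c1cc(OC)c(OC)c(OC)c1` gives 21300 nM. Within the data shown here, the only measured step is a 1.8-fold lower number from compound 2 to compound 3 (0.24 log units; within the scatter), which leaves compound 3 level with compound 2. That step concerns (the fact that compounds 2 and 3 differ only in the configuration as drawn), and the entries for compound 1 show how far repeats of a single structure can spread.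

Compound 4 `COc1cc([C@H]2C[C@]2(CO)C(=O)Nc2ccccc2)cc(OC)c1OC` has not yet been measured. It differs from compound 3 as follows: hydroxymethyl in place of ethoxycarbonyl on a saturated ring carbon. Among the measured compounds shown here, this places hydroxymethyl in place of ethoxycarbonyl on a saturated ring carbon, and no measured compound changes this group. For the measured compounds named here, the data therefore give no direction for the change, and the one available step, a 1.8-fold lower number from compound 2 to compound 3 (0.24 log units; within the scatter), speaks only to configuration. No step beyond the scatter is expected in this assay, although the uncertainty is wide. The expected step is a 1.4-fold higher number from compound 3 to compound 4 (0.15 log units; within the scatter). Compound 4 is estimated at 30000 nM, with an expected range of 10000 nM to 90000 nM.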

Compound 4, half-maximal inhibitory concentration: > 100000 nM
Compound 4 was reported as a limit (the forecaster's own chance of this, stated with the estimate: 15%); at least 3.3-fold (0.52 log units) between middle value and limit.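

In this assay, the exchange of ethoxycarbonyl for hydroxymethyl on this saturated ring carbon gives an at least 4.6-fold higher number from compound 3 to compound 4 (0.67 log units; beyond the scatter). Among these compounds, it is the first change at this carbon to be read, and unlike the change of configuration, which gave a 1.8-fold lower number from compound 2 to compound 3 (0.24 log units; within the scatter), it goes beyond the scatter, so the group held here matters more to this number than the configuration as drawn. The full size of the step stays unknown, as the value for compound 4 is a limit and not a number: the limit of > 100000 nM in this assay, at which 1 of the 4 values shown sits.

The compounds shown do not tell whether the loss follows from removing the ester or from the hydroxymethyl itself, and a carboxylic acid, a primary amide or a plain methyl group on this carbon would help to separate the two. They also leave open whether hydroxymethyl behaves the same way in the configuration of compound 2.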